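A Furan for a Thiophene at the Assay Limit

A few compounds are considered here, and "the series" means these few. Any claim that something is new, unique, unknown or untested is made for them only; others in the source may bear on it.

Of the compounds shown here, three have been read in a functional assay on HCT-116 cells (Homo sapiens) for cytotoxicity, read by MTT assay (a higher number here means a weaker inhibitor, a lower number a stronger inhibitor), so far. Compound 1 (`Cc1cc(O)c(C(=O)/C=C/c2ccccc2)c(=O)o1`) gives > 100000 nM as a limit of the assay and not a number. Compound 2 (`Cc1cc(O)c(C(=O)/C=C/c2ccccc2F)c(=O)o1`) gives > 100000 nM as a limit too. Compound 3 (`Cc1cc(O)c(C(=O)/C=C/c2cccs2)c(=O)o1`) gives > 100000 nM as a limit as well, so it stands with the other two, and the data show the limit of > 100000 nM in this assay, at which 3 of the 3 values shown sit, without a single numeric value.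

Compound 4 (`Cc1cc(O)c(C(=O)/C=C/c2ccco2)c(=O)o1`) carries furan-2-yl in place of thiophen-2-yl on a double-bonded chain carbon bound to a double-bonded chain carbon.

The closest measured change is a step that the two limits leave unreadable from compound 1 to compound 3 in the same place. The other is a step that the two limits leave unreadable from compound 1 to compound 2 on the aromatic ring. Neither has a readable size, so no step beyond the scatter is expected, and the assay may well report only a limit again. The expected step is a number no higher from compound 3 to compound 4 (the limit leaves the size open) with no direction that these data can support. Compound 4 is estimated at 100000 nM with an expected range from 40000 nM to 150000 nM in this reading.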

Compound 4, half-maximal inhibitory concentration: > 100000 nM
Compound 4 ended at the assay's limit; the forecaster's own chance of this, stated with the estimate: 80%; the middle value sits exactly at the limit.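

In this assay compound 4 gives > 100000 nM, a limit of the assay and not a number, so its steps from compound 1 and compound 3 cannot be read. The compounds shown leave open whether furan-2-yl, thiophen-2-yl or phenyl at this place makes any difference.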